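The compounds below may be only part of what the source reports. "The series", "measured", "known", "first", "only" and "open" are said of these compounds alone.

Series notes, cytotoxicity. Compound 1 `COc1ccc(-c2cnc(NC(=O)C3CCCCC3)n2C)cc1` carries cyclohexyl on a carbonyl carbon. In a toxicity assay on THP-1 cells (Homo sapiens) for inhibition (on this read-out higher numbers stand for lower toxicity in this test and lower numbers for higher toxicity in this test), compound 1 reaches only a limit of the assay, > 100000 nM. Compound 2 `COc1ccc(-c2cnc(NC(=O)c3cccc(OC)c3)n2C)cc1` carries 3-methoxyphenyl in place of cyclohexyl on a carbonyl carbon; the step that the two limits leave unreadable from compound 1 to compound 2 is unreadable, both ends being limits. In this assay compound 2 likewise gives only a limit, > 100000 nM. Compound 2 thus stands at the limit of > 100000 nM in this assay, at which 2 of the 3 values shown sit. Within the data shown here, compound 3 `Cn1c(-c2cccc(F)c2)cnc1NC(=O)c1ccc(F)cc1` is the one measured number: in this assay compound 3 gives 58000 nM. Compound 4 `COc1ccc(-c2cnc(NC(=O)c3ccccn3)n2C)cc1` differs from compound 2 by pyridin-2-yl in place of 3-methoxyphenyl on a carbonyl carbon. Among the measured compounds shown here, no measured step covers an exchange of this kind on the carbonyl carbon; the only step that changes that position is unreadable, and two of the three values are limits with the third a measured number, so no movement beyond the scatter is expected. Compound 4 is therefore expected at 100000 nM, range 40000 nM to 300000 nM, most likely again reported only as a limit. The expected step from compound 2 to compound 4 is a number no higher from compound 2 to compound 4 (the limit leaves the size open).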

Compound 4, half-maximal cytotoxic concentration: > 100000 nM
Compound 4: a limit, no number (the forecaster's own chance of this, stated with the estimate: 70%); the middle value sits exactly at the limit.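

With compound 1, compound 2 and compound 4 all reported only as limits in this assay, no step among these three compounds can be read. The compounds shown leave open whether any exchange on the carbonyl carbon moves the half-maximal cytotoxic concentration at all.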